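The source may report more compounds than this note shows. Statements on the series, on what has been measured and on what is new or still open speak of the compounds shown alone.

Three compounds share one core and differ only in the group attached to a carbonyl carbon. In a functional assay on MIA PaCa-2 cells (Homo sapiens) for inhibition, read by MTT assay, with a stated time of 3 days (a higher number here means a weaker inhibitor, a lower number a stronger inhibitor), compound 1 `CCN(CC)S(=O)(=O)c1ccc(S(=O)(=O)N2CCC[C@@H](C(=O)N3CCOCC3)C2)cc1` gives 160 nM. Compound 2 `CCN(CC)S(=O)(=O)c1ccc(S(=O)(=O)N2CCC[C@@H](C(=O)N[C@@H]3CCOC3)C2)cc1` gives 100 nM in this assay. Compound 3 `CCN(CC)S(=O)(=O)c1ccc(S(=O)(=O)N2CCC[C@@H](C(=O)N3CCS(=O)(=O)CC3)C2)cc1` gives 220 nM in this assay, the highest number of the three. The step of a 1.4-fold higher number from compound 1 to compound 3 (0.14 log units; within the scatter) lies within the scatter, while the step of a 2.2-fold higher number from compound 2 to compound 3 (0.34 log units; beyond the scatter) is a modest one beyond it; the step of a 1.6-fold lower number from compound 1 to compound 2 (0.20 log units; within the scatter) also lies within the scatter.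

Compound 4 `CCN(CC)S(=O)(=O)c1ccc(S(=O)(=O)N2CCC[C@@H](C(=O)N3CCC(C(F)F)CC3)C2)cc1` has not yet been measured. It differs from compound 3 by 4-(difluoromethyl)piperidin-1-yl in place of 1,1-dioxothiomorpholin-4-yl on a carbonyl carbon. Going by the values given here, none of the measured steps exchanges a ring on this carbonyl for one without hydrogen-bond acceptors, so none bears directly on this change. What they do show is that swapping one group for another at this position has moved the number in this assay only a little, in either direction. On that basis the step from compound 3 to compound 4 is expected to be small, a 1.1-fold lower number from compound 3 to compound 4 (0.04 log units; within the scatter), with no direction that can be stated beyond the scatter. Compound 4 is therefore estimated at 200 nM in this assay, within a range from 80 nM to 500 nM.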

Compound 4, half-maximal inhibitory concentration: 140 nM
For compound 4 the middle estimate is 1.4-fold (0.15 log units) above the measured one; the measured number falls inside the stated range.
By their numbers in this assay, from the lowest: compounds 2, 4, 1 and 3 (each within the scatter of the next, the first and the last beyond it).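

In this assay, 4-(difluoromethyl)piperidin-1-yl, with no hydrogen-bond acceptors, replaces 1,1-dioxothiomorpholin-4-yl, which has two, and the result is a 1.6-fold lower number from compound 3 to compound 4 (0.20 log units; within the scatter), so the acceptors of the leaving ring are not required for a number in this range. Set against the other two compounds, the same group gives a 1.4-fold higher number from compound 2 to compound 4 (0.15 log units; within the scatter) and a 1.1-fold lower number from compound 1 to compound 4 (0.06 log units; within the scatter), which places compound 4 within the scatter of all three earlier compounds, even though compound 2 and compound 3 lie beyond the scatter of each other. No measurement beyond these cell numbers is available to explain this tolerance at the carbonyl carbon.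

The compounds shown leave open what the difluoromethyl group itself contributes, since that would take a comparison with plain piperidin-1-yl or with 4-methylpiperidin-1-yl. They also leave open whether the number stays in this narrow band with a piperazine ring carrying a free amine, a carboxylic acid on the ring, or an open diethylamino group on this carbonyl carbon.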